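Trisubstituted phenyl triazole thioethers tested on prostate cancer cells

A few compounds are considered here, and "the series" means these few. Any claim that something is new, unique, unknown or untested is made for them only; others in the source may bear on it.

Compound 1 `COc1ccc(-n2c(SCC(=O)c3ccc(F)cc3)nnc2-c2cc(OC)c(OC)c(OC)c2)cc1` is the starting point; in a functional assay on PC-3 cells (Homo sapiens) for inhibition, read by MTT assay, with a stated time of 48 h (on this read-out lower numbers stand for stronger inhibition and higher numbers for weaker inhibition), compound 1 gives 58300 nM. Compound 3 `COc1cc(-c2nnc(SCC(=O)c3ccc(F)cc3)n2-c2ccc(N(C)C)cc2)cc(OC)c1OC` differs from it by dimethylamino in place of methoxy on an aromatic carbon, and in this assay compound 3 gives 42300 nM, a step of a 1.4-fold lower number from compound 1 to compound 3 (0.14 log units; within the scatter). Compound 2 `COc1ccc(-n2c(SCC(=O)c3ccc(OC)c(O)c3)nnc2-c2cc(OC)c(OC)c(OC)c2)cc1` carries 3-hydroxy-4-methoxyphenyl in place of 4-fluorophenyl on a carbonyl carbon relative to compound 1. Compound 2 reaches only a limit of this assay, > 60000 nM. The step is an at least 1.0-fold higher number from compound 1 to compound 2 (0.01 log units; that floor lies within the scatter), resting on (the limit of > 60000 nM in this assay, at which 1 of the 3 values shown sits).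

Compound 4 `COc1ccc(C(=O)CSc2nnc(-c3cc(OC)c(OC)c(OC)c3)n2-c2ccc(N(C)C)cc2)cc1O` has not yet been measured. It differs from compound 3 by 3-hydroxy-4-methoxyphenyl in place of 4-fluorophenyl on a carbonyl carbon, the same change that leads from compound 1 to compound 2. Compound 4 is therefore expected to show a step of about a 1.4-fold higher number from compound 3 to compound 4 (0.15 log units; within the scatter), because an at least 1.0-fold higher number from compound 1 to compound 2 (0.01 log units; that floor lies within the scatter) gave no gain and ended at the limit of > 60000 nM in this assay, at which 1 of the 3 values shown sits. Compound 4 is estimated at 60000 nM, between 35000 nM and 110000 nM, with a real chance that only a limit is reported.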

Compound 4, half-maximal inhibitory concentration: > 100000 nM
Compound 4 was reported as a limit (the forecaster's own chance of this, stated with the estimate: 55%); at least 1.6-fold (0.22 log units) between middle value and limit.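

Placing 3-hydroxy-4-methoxyphenyl in place of 4-fluorophenyl on the carbonyl carbon of the core of compound 3 gave an at least 2.3-fold higher number from compound 3 to compound 4 (0.37 log units; beyond the scatter) in this assay. The change therefore brought no gain on either core, but this does not show that it costs the same on both: the same change on two cores in this assay, an at least 1.0-fold higher number (0.01 log units; that floor lies within the scatter) from compound 1 to compound 2 and an at least 2.3-fold higher number (0.37 log units; beyond the scatter) from compound 3 to compound 4; the limit leaves it open whether they differ

Compound 2 and compound 4 are both limits of the assay, and the step between them cannot be read.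

The compounds shown leave open whether 3-hydroxyphenyl alone or 4-methoxyphenyl alone on the carbonyl carbon would behave like the combined group. They also leave open how an amine or a carboxylic acid at that place would read on either core.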